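A Thiophene Ring in Place of Phenyl

This account rests on a few compounds, and the source may have more. Where it says the series, first, only, none or still open, it means among the compounds named here.

The shared core of compound 1 `CCS[C@@H]1[C@H](SCC)[C@@H](Cn2cc(-c3ccccc3)nn2)O[C@H]1n1ccc(=O)[nH]c1=O` carries a phenyl group on an aromatic carbon of a five-membered aromatic ring with 3 nitrogen. Among the measured compounds shown here, in a functional assay on HeLa cells (Homo sapiens) for cytotoxicity, read by MTT assay, with a stated time of 72 h (a higher number here means that more compound is needed for the effect, a lower number that less compound is needed), compound 1 gives 6590 nM, the lowest of the three numbers measured so far. Compound 2 `CCS[C@@H]1[C@H](SCC)[C@@H](Cn2cc(-c3ccccc3C(F)(F)F)nn2)O[C@H]1n1ccc(=O)[nH]c1=O`, which bears a trifluoromethyl in place of hydrogen on an aromatic carbon, gives 32800 nM, and compound 3 `CCS[C@@H]1[C@H](SCC)[C@@H](Cn2cc(-c3cccc(C)c3)nn2)O[C@H]1n1ccc(=O)[nH]c1=O`, with a methyl in place of hydrogen on an aromatic carbon, gives 18800 nM. Both steps away from compound 1 raised the number: a 5.0-fold higher number from compound 1 to compound 2 (0.70 log units; beyond the scatter) and a 2.9-fold higher number from compound 1 to compound 3 (0.46 log units; beyond the scatter). The remaining measured step is a 1.7-fold lower number from compound 2 to compound 3 (0.24 log units; within the scatter).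

Compound 4 `CCS[C@@H]1[C@H](SCC)[C@@H](Cn2cc(-c3cccs3)nn2)O[C@H]1n1ccc(=O)[nH]c1=O` departs from compound 1 in a different way: thiophen-2-yl in place of phenyl on an aromatic carbon. Neither measured step bears directly on this change, since both added a group to the phenyl rather than exchanging the ring itself. What the two steps do show is that each departure from compound 1 so far has raised the number by a modest amount. On that basis the expected step is a 1.4-fold higher number from compound 1 to compound 4 (0.14 log units; within the scatter), a small rise at most or none beyond the scatter. Compound 4 is therefore estimated at 9000 nM in this assay, with a range from 3500 nM to 25000 nM.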

Compound 4, half-maximal effective concentration: >= 100000 nM
Compound 4: a limit, no number; the forecaster's own chance of this, stated with the estimate: 5%; middle value at least 11-fold (1.04 log units) from the limit.
By their numbers in this assay, from the lowest: compound 1; then compounds 3 and 2 (each within the scatter of the next). At a limit, above all of these: compound 4.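

In this assay compound 4 stands at a limit of the assay and not at a number: the limit of >= 100000 nM in this assay, at which 1 of the 4 values shown sits.

Exchanging the ring itself on an aromatic carbon of the five-membered aromatic ring with 3 nitrogen, with phenyl leaving and thiophen-2-yl entering, gives an at least 15-fold higher number from compound 1 to compound 4 (1.18 log units; beyond the scatter), a large step and the only one of that size among these compounds, whereas adding a group to the phenyl gave modest steps. The two substituted phenyl compounds also stay clear of the limit, with an at least 5.3-fold higher number from compound 3 to compound 4 (0.72 log units; beyond the scatter) and an at least 3.0-fold higher number from compound 2 to compound 4 (0.48 log units; beyond the scatter), so in this small set the number at this position responds more strongly to exchanging the phenyl ring than to adding trifluoromethyl or methyl to it.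

Thiophen-2-yl differs from phenyl in ring size and in its sulfur at once, and these compounds cannot separate the two. Also open, from the compounds shown here alone, is how a pyridine ring or a furan ring in this place, or an amine or a carboxylic acid on the phenyl, would read in this assay.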